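Nitro in Place of Hydroxy: What to Expect

A few compounds are considered here, and "the series" means these few. Any claim that something is new, unique, unknown or untested is made for them only; others in the source may bear on it.

Of the compounds shown here, three built on one shared core have been measured in an assay on CHO cells for inhibition of 3-oxo-5-alpha-steroid 4-dehydrogenase 2 (Homo sapiens); on this read-out lower numbers stand for stronger inhibition and higher numbers for weaker inhibition. Compound 1 `O=C(O)c1ccc(C(=O)c2ccc(C(=O)c3ccccc3)cc2)cc1` gives 40 nM. Compound 2 `O=C(O)c1ccc(C(=O)c2ccc(C(=O)c3ccc(O)cc3)cc2)cc1`, which carries a hydroxy group, gives 22 nM. Compound 3 `O=C(O)c1ccc(C(=O)c2ccc(C(=O)c3ccc(C(F)(F)F)cc3)cc2)cc1`, which carries a trifluoromethyl group instead, gives 30 nM. Compound 2 has the lowest of the three numbers, yet each step connecting it to the others lies within the scatter: a 1.8-fold lower number from compound 1 to compound 2 (0.26 log units; within the scatter), and a 1.4-fold higher number from compound 2 to compound 3 (0.13 log units; within the scatter). The remaining step, a 1.3-fold lower number from compound 1 to compound 3 (0.12 log units; within the scatter), is small as well.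

Compound 4 `O=C(O)c1ccc(C(=O)c2ccc(C(=O)c3ccc([N+](=O)[O-])cc3)cc2)cc1` has not yet been measured. It differs from compound 2 in a single place: nitro in place of hydroxy on an aromatic carbon. All three measured steps bear on this change, since each of them exchanges one group for another on an aromatic carbon of the same ring, and none of them moved the number beyond the scatter. Nothing in these data sets a nitro group apart from the groups already tried, so the step from compound 2 to compound 4 is expected to stay within the scatter as well: a 1.4-fold higher number from compound 2 to compound 4 (0.13 log units; within the scatter). For compound 4 the estimate in this assay is 30 nM, with a range from 12 nM to 75 nM.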

Compound 4, inhibition constant: 100 nM
Compound 4: middle estimate off by 3.3-fold (0.52 log units), on the low side; measured number outside the range, above it.
By their numbers in this assay, from the lowest: compounds 2, 3 and 1 (each within the scatter of the next); then compound 4.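

Hydrogen, hydroxy and trifluoromethyl left the numbers in this assay within the scatter of one another, so this position, on an aromatic carbon para to a large group, could have seemed to accept any of the groups placed there. Nitro shows that the choice of group can matter here, with a 4.5-fold higher number from compound 2 to compound 4 (0.66 log units; beyond the scatter), a 3.3-fold higher number from compound 3 to compound 4 (0.52 log units; beyond the scatter) and a 2.5-fold higher number from compound 1 to compound 4 (0.40 log units; beyond the scatter). All three steps are modest, but each lies beyond the scatter and points the same way, which makes compound 4 the weakest of the four and sets nitro apart from the three groups tried before it, and no measurement shown here says what lies behind this difference.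

The four compounds cannot show whether the higher number is particular to nitro or would also appear with another group at this position, such as a nitrile, an amine or a carboxylic acid. They also leave open whether nitro would give a similar step on a different carbon of the same ring, since all the groups shown occupy this one position.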